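A few compounds are considered here, and "the series" means these few. Any claim that something is new, unique, unknown or untested is made for them only; others in the source may bear on it.

Compound 1 `COCCN(C)S(=O)(=O)c1ccc(C)c(C#Cc2cc(Cl)ccc2OCC(=O)O)c1`: 4.1 nM
Compound 2 `C[S+]([O-])c1cccc(C#Cc2cc(Cl)ccc2OCC(=O)O)c1`: 3.2 nM
Compound 3 `O=C(O)COc1ccc(Cl)cc1C#Cc1ccccc1`: 108 nM

In an assay on CHO cells for displacement of a labelled ligand from prostaglandin D2 receptor 2 (Homo sapiens), read by scintillation counting (on this read-out higher numbers stand for weaker inhibition and lower numbers for stronger inhibition), compound 1 stands second highest of the three numbers; its value and that of compound 2 lie within the scatter of each other, while compound 3 gives a far higher number. Compound 4 `CNS(=O)(=O)c1ccc(C)c(C#Cc2cc(Cl)ccc2OCC(=O)O)c1` differs from compound 1 in one place: hydrogen in place of 2-methoxyethyl on a sulfonamide nitrogen. Among the measured compounds shown here, the only measured step, a 34-fold higher number from compound 2 to compound 3 (1.53 log units; beyond the scatter), concerns removing a group from an aromatic carbon, not trimming a chain on a sulfonamide nitrogen, so it offers little guidance here. Since the sulfonamide itself stays in place, compound 4 is expected to show a 1.5-fold higher number from compound 1 to compound 4 (0.17 log units; within the scatter), a change that may stay within the scatter. Compound 4 is therefore estimated at 6 nM, likely between 2 nM and 20 nM.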

Compound 4, inhibition constant: 10 nM
Beside the measured number, compound 4's estimate is 1.7-fold (0.22 log units) below it, within the range that was stated.
By their numbers in this assay, from the lowest: compounds 2 and 1 (each within the scatter of the next); then compound 4; then compound 3.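

In this assay, putting hydrogen in place of 2-methoxyethyl on the sulfonamide nitrogen gives a 2.4-fold higher number from compound 1 to compound 4 (0.39 log units; beyond the scatter), so this chain has a measurable effect on the number. The step is modest, however: much of the binding measured for compound 1 survives without the chain. Nothing measured here explains the change. Still open, from the compounds shown here alone, is how the number would respond to an ethyl group, a longer ether chain or a chain ending in an amine on this nitrogen. Also open, going by these compounds, is whether a sulfonamide with two nitrogen hydrogens would hold the number of compound 4.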